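A few compounds are considered here, and "the series" means these few. Any claim that something is new, unique, unknown or untested is made for them only; others in the source may bear on it.

Measured so far: compound 1 `O=C(Nc1nc2ccc(F)cc2s1)c1cn(-c2ccccc2)nc1-c1ccccc1`, 5570 nM; compound 2 `Cc1ccc2nc(NC(=O)c3cn(-c4ccccc4)nc3-c3ccccc3)sc2c1`, 23200 nM.

For the measured compounds named here, compound 2 holds the higher of these two numbers, the single measured step being a 4.2-fold higher number from compound 1 to compound 2 (0.62 log units; beyond the scatter). Compound 3 `Cc1ccc2nc(NC(=O)c3cn(-c4ccccc4)nc3-c3ccc(Cl)cc3)sc2c1` differs from compound 2 by chloro in place of hydrogen on an aromatic carbon. Going by the values given here, that change sits on the other phenyl ring, which neither measured compound varies, so the one measured step does not bear on it, and no shift in a functional assay on U-87MG ATCC cells for cytotoxicity against U-87 MG (Homo sapiens), read by MTT assay, with a stated time of 72 h (a higher number here means a weaker inhibitor, a lower number a stronger inhibitor), beyond the scatter is expected. The expected step is a 1.2-fold lower number from compound 2 to compound 3 (0.06 log units; within the scatter). Compound 3 is therefore estimated at 20000 nM, within 7000 nM to 60000 nM.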

Compound 3, half-maximal inhibitory concentration: 33200 nM
The estimate for compound 3 lay 1.7-fold (0.22 log units) below the measured number; measured number inside the range.
By their numbers in this assay, from the lowest: compound 1; then compounds 2 and 3 (each within the scatter of the next).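

In this assay, for the compounds shown here, going from phenyl to 4-chlorophenyl on the ring that the earlier compounds left unvaried gives a 1.4-fold higher number from compound 2 to compound 3 (0.16 log units; within the scatter). Chloro in place of hydrogen at this place, para to a large group, therefore stays within the scatter, so this position tolerates the change without a shift that can be read. Nothing at hand accounts for this result.

On these data alone, it remains open whether an amine, a methoxy group or a carboxylic acid at this place would behave as chloro does. As far as these compounds go, it is also open whether chloro here would read the same alongside the fluoro of compound 1.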